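A few compounds are considered here, and "the series" means these few. Any claim that something is new, unique, unknown or untested is made for them only; others in the source may bear on it.

Three compounds share one core and differ only in the ester side chain. Compound 1 `C=C1CC[C@@H]2[C@](C)(CO)[C@H](O)CC[C@@]2(C)[C@@H]1C/C=C1/C(=O)OC[C@H]1OC(=O)CSc1ccc(C)cc1` gives 27000 nM in a functional assay on PC-3 cells (Homo sapiens) for inhibition, read by MTT assay, with a stated time of 48 h; on this read-out higher numbers stand for weaker inhibition and lower numbers for stronger inhibition. Compound 2 `C=C1CC[C@@H]2[C@](C)(CO)[C@H](O)CC[C@@]2(C)[C@@H]1C/C=C1/C(=O)OC[C@H]1OC(=O)CCCSc1ccc(OC)cc1` gives 19000 nM in this assay, and compound 3 `C=C1CC[C@@H]2[C@](C)(CO)[C@H](O)CC[C@@]2(C)[C@@H]1C/C=C1/C(=O)OC[C@H]1OC(=O)CCCSc1ccc([N+](=O)[O-])cc1` gives 17000 nM. Among the three numbers, compound 3 gives the lowest, yet every step leading to it stays within the scatter: a 1.4-fold lower number from compound 1 to compound 2 (0.15 log units; within the scatter), a 1.6-fold lower number from compound 1 to compound 3 (0.20 log units; within the scatter), and a 1.1-fold lower number from compound 2 to compound 3 (0.05 log units; within the scatter). None of these changes moved the number further than repeated measurement alone would.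

Compound 4 `C=C1CC[C@@H]2[C@](C)(CO)[C@H](O)CC[C@@]2(C)[C@@H]1C/C=C1/C(=O)OC[C@H]1OC(=O)CCCSc1ccc(C)cc1` has not been measured yet. It differs from compound 3 in one place: methyl in place of nitro on an aromatic carbon. The measured step closest to this change is a 1.1-fold lower number from compound 2 to compound 3 (0.05 log units; within the scatter), where one group on that same aromatic carbon was swapped for another and the number stayed within the scatter. The steps of a 1.4-fold lower number from compound 1 to compound 2 (0.15 log units; within the scatter) and a 1.6-fold lower number from compound 1 to compound 3 (0.20 log units; within the scatter), which also changed the group on that ring along with the chain, were likewise within the scatter. Nothing among these compounds suggests that exchanging the group on that aromatic carbon moves the number beyond the scatter. The expected step is therefore a 1.2-fold higher number from compound 3 to compound 4 (0.07 log units; within the scatter). Compound 4 is estimated at 20000 nM, with a range from 9000 nM to 45000 nM in this assay.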

Compound 4, half-maximal inhibitory concentration: 16000 nM
Estimate against measurement, compound 4: 1.3-fold (0.10 log units) above; measured number inside the range.
By their numbers in this assay, from the lowest: compounds 4, 3, 2 and 1 (each within the scatter of the next).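

With the chain held fixed, the group on this aromatic carbon has now been exchanged among three options, and in this assay methyl in place of nitro gives a step within the scatter (a 1.1-fold lower number from compound 3 to compound 4 (0.03 log units; within the scatter)), as does methyl in place of methoxy (a 1.2-fold lower number from compound 2 to compound 4 (0.07 log units; within the scatter)). Nitro, methoxy and methyl are thus interchangeable at this position in this assay, a reading that until now rested on a single pair. Within the data shown here, the result also gives the first step with the same 4-methylphenyl group at both ends, so that only the chain differs: 2-((4-methylphenyl)sulfanyl)ethyl in place of (4-methylphenyl)sulfanyl also stays within the scatter (a 1.7-fold lower number from compound 1 to compound 4 (0.23 log units; within the scatter)), and no information is available on why these exchanges leave the number where it is.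

The compounds shown leave open whether a quite different group on that aromatic carbon, such as an amine or a carboxylic acid, would move the number beyond the scatter. They also leave open whether a longer chain in the ester side chain would do so.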